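The source may hold more compounds than are shown below. What is called first, only, known or untested is meant among the compounds shown, and "the series" means these compounds.

Measured compounds:
compound 1, `COc1ccc(-c2cc(=O)c3c(OC)cc(OC)cc3n2C)cc1`, 30000 nM
compound 2, `COc1ccc(-c2cc(=O)c3c(OC)cc(OC)cc3n2S(=O)(=O)c2ccc(C)cc2)cc1`, limit > 44800 nM

In a functional assay on KOPN-8 cells (Homo sapiens) for antiproliferative activity, with a stated time of 72 h (a higher number here means that more compound is needed for the effect, a lower number that less compound is needed), compound 1 gives 30000 nM. For compound 2 this assay reports only a limit, > 44800 nM, so no number is known for it. Going by the values given here, the single measured step, an at least 1.4-fold higher number from compound 1 to compound 2 (0.17 log units; that floor lies within the scatter), is therefore only a floor, and compound 2 stands at the limit of > 44800 nM in this assay, at which 1 of the 2 values shown sits. Compound 3, `COc1ccc(-c2cc(=O)c3c(OC)cc(OC)cc3n2S(=O)(=O)c2ccc(OC)cc2)cc1`, differs from compound 2 by methoxy in place of methyl on an aromatic carbon. Among the compounds with values here, no measured step touches this position: the one known step concerns the group on the aromatic nitrogen, not the ring it carries, so nothing measured bears directly on the change. Because compound 2 stands at the limit of > 44800 nM in this assay, at which 1 of the 2 values shown sits, compound 3 is expected to remain at or beyond that limit as well. The expected step is a step that the limit leaves unreadable from compound 2 to compound 3, no more than the scatter. Compound 3 is thus estimated at 55000 nM, with a range from 20000 nM to 150000 nM.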

Compound 3, half-maximal effective concentration: > 82700 nM
Compound 3 ended at the assay's limit (the forecaster's own chance of this, stated with the estimate: 75%); middle value at least 1.5-fold (0.17 log units) away from the limit.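

Replacing the methyl on the aromatic nitrogen with (4-methoxyphenyl)sulfonyl gives an at least 2.7-fold higher number from compound 1 to compound 3 (0.44 log units; beyond the scatter), so a swap at this nitrogen now has a floor past the scatter, which the (4-methylphenyl)sulfonyl step did not reach. Compound 3 reports only a limit and no number: the limit of > 82700 nM in this assay, at which 1 of the 3 values shown sits. The change from methyl to methoxy on the aromatic carbon itself cannot be read, as compound 2 and compound 3 both carry only limits, so neither its size nor its direction is known.

As far as these compounds go, how far compound 2 and compound 3 lie past their limits stays open. Also open, from the compounds shown here alone, is what an amine or a carboxylic acid on that same aromatic carbon would give in this assay, and whether any such group would bring the number down to that of compound 1 or lower.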